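Pyridin-4-yl in place of the five-membered aromatic group

This account rests on a few compounds, and the source may have more. Where it says the series, first, only, none or still open, it means among the compounds named here.

Measured so far in a functional assay on ileum (Cavia porcellus) for inhibition; on this read-out higher numbers stand for weaker inhibition and lower numbers for stronger inhibition
- compound 1 `COC(=O)C1=C(C)NC(C)=C(C(=O)OC)C1c1c(-c2ccccn2)nc2sccn12` gives 2570 nM
- compound 2 `COC(=O)C1=C(C)NC(C)=C(C(=O)OC)C1c1c(-c2c(Cl)csc2Cl)nc2sccn12` gives 180 nM

Compound 2 holds the lower of the two numbers (at 180 nM). Compound 3 `COC(=O)C1=C(C)NC(C)=C(C(=O)OC)C1c1c(-c2ccncc2)nc2sccn12` is not yet measured. Its change from compound 2 is a group of 6 heavy atoms (5 carbon, 1 nitrogen; one six-membered aromatic ring with 1 hetero atom) in place of a group of 7 heavy atoms (4 carbon, 1 sulfur, 2 chlorine; one five-membered aromatic ring with 1 hetero atom), on an aromatic carbon and the group that enters is pyridin-4-yl. For the measured compounds named here, one measured step bears on this (namely a 14-fold lower number from compound 1 to compound 2 (1.15 log units; beyond the scatter)), where a six-membered aromatic ring with 1 hetero atom gave way to the same group that now leaves. The step was large. The reverse exchange is therefore expected to give a large step to a higher number in this assay, though compound 3 does not carry the group of compound 1, so the match may be incomplete. The expected change is (as estimated) an 8.3-fold higher number from compound 2 to compound 3 (0.92 log units; beyond the scatter). For compound 3 the estimated value is 1500 nM (expected range 400 nM to 5500 nM).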

Compound 3, half-maximal inhibitory concentration: 960 nM
Compound 3: middle estimate off by 1.6-fold (0.19 log units), on the high side, within the range that was stated.
By their numbers in this assay, from the lowest: compound 2; then compound 3; then compound 1.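

In this assay pyridin-4-yl in place of the five-membered aromatic group gives a 5.3-fold higher number from compound 2 to compound 3 (0.73 log units; beyond the scatter), so this aromatic carbon does not tolerate every six-membered aromatic ring with a hetero atom equally. Pyridin-4-yl in place of pyridin-2-yl gives a 2.7-fold lower number from compound 1 to compound 3 (0.43 log units; beyond the scatter), which shows that, with the ring size and heavy-atom count unchanged, the location of the ring nitrogen alone moves the number beyond the scatter. No measurement on hand accounts for either step.

On these data alone, whether the lower number of compound 2 goes with the two chlorine atoms or with the sulfur-containing ring remains open. A chlorine-free thienyl group and a phenyl group carrying two chlorine atoms at this position would separate the two, and an unsubstituted phenyl group would show what the pyridine ring nitrogen contributes.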